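A few compounds are considered here, and "the series" means these few. Any claim that something is new, unique, unknown or untested is made for them only; others in the source may bear on it.

Compound 1 `CN(C)c1cc2[nH]c(C3CCCCC3)nc2cc1NC(=O)c1ccccc1`: in an ADME assay on Vero cells (Chlorocebus sabaeus) for cytotoxicity, read by resazurin assay, with a stated time of 3 days (a lower number here means a stronger inhibitor, a higher number a weaker inhibitor), compound 1 reaches only > 100 ug/mL, which is a limit of the assay and not a number.
Compound 2 `CCN(CC)c1cc2[nH]c(C3CCCCC3)nc2cc1NC(=O)NCc1ccccc1`: in this assay compound 2 also reaches only > 100 ug/mL, again a limit.
Compound 3 `O=C(NCc1ccccc1)Nc1cc2nc(C3CCCCC3)[nH]c2cc1N1CCCC1`: in this assay compound 3 gives > 100 ug/mL, likewise a limit.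

Compound 3 therefore stands where every measured compound stands, at the limit of > 100 ug/mL in this assay, at which 3 of the 3 values shown sit. Among the measured compounds shown here, the only measured step that touches compound 3 is a step that the two limits leave unreadable from compound 2 to compound 3. Both ends of that step sit at a limit, and its size cannot be read. Compound 4 `O=C(Nc1cc2nc(C3CCCCC3)[nH]c2cc1N1CCCC1)c1ccccc1` differs from compound 3 by one change, (phenyl in place of benzylamino on a carbonyl carbon). No measured step follows this change in this assay, so nothing shown can give its size or direction; the three limits only say that the shared core, with either a benzoyl or a benzylcarbamoyl group, has not shown cytotoxicity within the range of this assay. Compound 4 is therefore expected to behave the same way, with an estimated step that the limit leaves unreadable from compound 3 to compound 4. The estimate for compound 4 in this assay is 150 ug/mL, with a range from 60 ug/mL to 400 ug/mL, and most likely the measurement will again come back as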

Compound 4, half-maximal inhibitory concentration: > 100 ug/mL
Compound 4 gave a limit, no number; the forecaster's own chance of this, stated with the estimate: 80%; the middle value does not contradict the limit.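

In this assay compound 4 gives > 100 ug/mL, which is a limit and not a number, so the steps to compound 4 from compound 3 and from compound 1 cannot be read. The compounds shown leave open what cytotoxicity value any of them would actually have and whether these changes alter it.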